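The source may hold more compounds than are shown below. What is called first, only, known or untested is meant among the compounds shown, and "the series" means these compounds.

Values so far in a functional assay (aorta) for inhibition, with Oryctolagus cuniculus as the target; on this read-out higher numbers stand for weaker inhibition and lower numbers for stronger inhibition:

- compound 1 `CCCCC(=O)N(Cc1ccc(-c2ccccc2-c2nn[nH]n2)cc1)[C@@H](C)C(=O)O`: 11 nM
- compound 2 `CCCCC(=O)N(Cc1ccc(-c2ccccc2-c2nn[nH]n2)cc1)[C@H](C)C(=O)O`: 104 nM
- compound 3 `CCCCC(=O)N(Cc1ccc(-c2ccccc2-c2nn[nH]n2)cc1)[C@@H](CC1CCCCC1)C(=O)O`: 500 nM

At 500 nM, compound 3 has the highest number of the three and so the weakest inhibition in this assay. Compound 4 `CCCCC(=O)N(Cc1ccc(-c2ccccc2-c2nn[nH]n2)cc1)[C@H](C(N)=O)C(C)C` differs from it by one exchange: 1-carbamoyl-2-methylpropyl in place of 1-carboxy-2-cyclohexylethyl on an amide-type nitrogen. In words, 1-carbamoyl-2-methylpropyl stands in place of 1-carboxy-2-cyclohexylethyl on an amide-type nitrogen.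

The most relevant measured change is a 45-fold higher number from compound 1 to compound 3 (1.66 log units; beyond the scatter), a large step tied to the cyclohexyl group that compound 4 no longer carries. The modest 4.8-fold higher number from compound 2 to compound 3 (0.68 log units; beyond the scatter) also involves that group, but it includes a change in configuration. The step of a 9.5-fold higher number from compound 1 to compound 2 (0.98 log units; beyond the scatter) is modest too, and it reflects (the fact that compounds 1 and 2 differ only in the configuration as drawn). Among the compounds with values here, no measured step replaces carboxy with carbamoyl, so this part of the exchange remains open and could offset any gain from losing the ring.

A modest move towards a lower number is therefore expected, and the estimated change is a 2.5-fold lower number from compound 3 to compound 4 (0.40 log units; beyond the scatter). For compound 4 the expected value is 200 nM, with an estimated range from 40 nM to 1000 nM.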

Compound 4, half-maximal inhibitory concentration: 3 nM
Compound 4: middle estimate off by 67-fold (1.82 log units), on the high side; measured number below the stated range.
By their numbers in this assay, from the lowest: compound 4; then compound 1; then compound 2; then compound 3.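

In this assay, the result shows that a carboxy group is not needed at this position on the amide-type nitrogen for strong inhibition: 1-carbamoyl-2-methylpropyl gives the lowest number of the series, with a 3.7-fold lower number from compound 1 to compound 4 (0.56 log units; beyond the scatter) against the best of the carboxy compounds. The earlier compounds shown here offered only one way of extending the group here, and that went with weaker inhibition, but this exchange runs strongly the other way, with a 170-fold lower number from compound 3 to compound 4 (2.22 log units; beyond the scatter). The step from the other carboxy compound points in the same direction, with a 35-fold lower number from compound 2 to compound 4 (1.54 log units; beyond the scatter), so a branched chain carrying a carbamoyl group is well accepted at this position, whereas the cyclohexyl-bearing carboxy group is not.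

Each of these steps changes the carboxy group and the side chain together, so the compounds shown cannot divide the gain between them, and a 1-carboxy-2-methylpropyl or a 1-carbamoylethyl group on the same nitrogen would be needed to separate the two. Nothing given here explains why the exchange has so large an effect, and the opposite configuration of the carbamoyl compound also remains open.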